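Combining the oxo core with the branched amine

The compounds below may be only part of what the source reports. "The series", "measured", "known", "first", "only" and "open" are said of these compounds alone.

Measured compounds:
Compound 1, `CCCN(CC1CC1)c1nc(C)nc2c1sc(=S)n2-c1ccc(C(C)C)cc1Br`, gives 12.6 nM in an assay on HEK293 cells for binding affinity to corticotropin-releasing factor receptor 1 (Homo sapiens); on this read-out higher numbers stand for weaker inhibition and lower numbers for stronger inhibition.
Compound 2, `CCN(CC)c1nc(C)nc2c1sc(=O)n2-c1ccc(C(C)C)cc1Br`, gives 9.4 nM in this assay.

Among the compounds with values here, only two compounds have been measured, and they differ from each other in two places at once, so no single step between them can be read off. On the numbers shown, compound 2 stands within the usual scatter of compound 1; the two figures cannot be told apart with confidence.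

Compound 3, `CCCN(CC1CC1)c1nc(C)nc2c1sc(=O)n2-c1ccc(C(C)C)cc1Br`, keeps the core of compound 2 and carries the change ((cyclopropylmethyl)(propyl)amino in place of diethylamino on an aromatic carbon). This is the same amine that compound 1 carries on its thione core, where compound 1 gives 12.6 nM. Since neither measured value separates from the other, no step beyond the scatter is expected from compound 2 to compound 3. The expected step in this assay is a 1.1-fold higher number from compound 2 to compound 3 (0.03 log units; within the scatter). For compound 3 the estimate in this assay is 10 nM, with a range from 4 nM to 25 nM.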

Compound 3, inhibition constant: 4.1 nM
Compound 3: the middle estimate sits 2.4-fold (0.39 log units) above what was measured; the measured number falls inside the stated range.
By their numbers in this assay, from the lowest: compound 3; then compounds 2 and 1 (each within the scatter of the next).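

In this assay, within the data shown here, the step of a 2.3-fold lower number from compound 2 to compound 3 (0.36 log units; beyond the scatter) is the first single change that can be read, and it shows that the amine on this aromatic carbon, next to the ring nitrogen, does affect the read-out, though only modestly. The change takes the group from 5 to 8 heavy atoms and adds a three-membered ring of carbon only, while the hydrogen-bond donor and acceptor counts and the absence of net charge stay the same, so the lower number comes with no difference in any of these counts. No measurement here bears on what lies behind this step, and the result therefore stays an observation.

The compounds shown do not separate the contributions of the two arms of the new amine, a question that dipropylamino and bis(cyclopropylmethyl)amino at the same place could settle. From the compounds shown here alone, it also remains open whether the step carries over to the core of compound 1, where reading it would take a diethylamino partner for that compound.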